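The compounds below may be only part of what the source reports. "The series", "measured", "known", "first", "only" and "open" are said of these compounds alone.

Measured compounds:
compound 1 `CC(C)(C)OC(=O)NCCNC(=O)CN1CN(c2ccccc2)C2(CCN(C(=O)c3ccc(C(C)(C)C)cc3)CC2)C1=O` — 10900 nM
compound 2 `CC(C)(C)OC(=O)NCCNC(=O)CN1CN(c2ccccc2)C2(CCN(C(=O)c3ccc(C4CCCCC4)cc3)CC2)C1=O` — 5500 nM
compound 3 `COC(=O)CCCNC(=O)CN1CN(c2ccccc2)C2(CCN(C(=O)c3ccc(C4CCCCC4)cc3)CC2)C1=O` — 2500 nM

In an assay on HEK293 cells for displacement of a labelled ligand from NPC1-like intracellular cholesterol transporter 1 (Homo sapiens) (a higher number here means a weaker inhibitor, a lower number a stronger inhibitor), compound 1 gives 10900 nM, the highest of the three numbers. The nearest step is a 2.0-fold lower number from compound 1 to compound 2 (0.30 log units; within the scatter). Compound 3 sits at a greater distance, with 2500 nM. Compound 4 `CC(C)(C)c1ccc(C(=O)N2CCC3(CC2)C(=O)N(CC(=O)N2CCCCC2CO)CN3c2ccccc2)cc1` differs from compound 1 in one place: 2-(hydroxymethyl)piperidin-1-yl in place of (2-((tert-butoxycarbonyl)amino)ethyl)amino on a carbonyl carbon. Within the data shown here, the one measured step that touches the same part of the shared core is the one in which the group on the chain two bonds from the amide-type nitrogen was exchanged, which gave a 2.2-fold lower number from compound 2 to compound 3 (0.34 log units; beyond the scatter). The other step, a 2.0-fold lower number from compound 1 to compound 2 (0.30 log units; within the scatter), concerns the far end of the molecule and says nothing about this position. Since a change at this end of the chain has so far moved this assay only modestly and towards lower numbers, a similar or smaller shift is expected here. For compound 4 the estimate is 6000 nM (2500 nM to 15000 nM), meaning an expected step of a 1.8-fold lower number from compound 1 to compound 4 (0.26 log units; within the scatter).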

Compound 4, half-maximal inhibitory concentration: 11800 nM
Beside the measured number, compound 4's estimate is 2.0-fold (0.29 log units) below it; measured number inside the range.
By their numbers in this assay, from the lowest: compound 3; then compounds 2, 1 and 4 (each within the scatter of the next, the first and the last beyond it).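

Compound 4 shows that this carbonyl carbon can carry a very different group in this assay: a chain with no ring and 11 heavy atoms gives way to a six-membered non-aromatic ring group with 8 heavy atoms, and the outcome is a 1.1-fold higher number from compound 1 to compound 4 (0.03 log units; within the scatter). The earlier step at this end of the molecule altered only the far part of the chain, whereas here the whole chain goes, including its amide-type nitrogen and tert-butoxycarbonyl group. No available evidence explains why these two different groups give values within the scatter of each other.

As far as these compounds go, it remains open whether plain piperidin-1-yl, without the hydroxymethyl, would behave the same way, or whether a chain ending in a carboxylic acid or a primary amine would. From the compounds shown here alone, the same exchange on the cyclohexyl-bearing compound 2 also remains open.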